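Bromo in place of tert-butyl on a benzyl group

The compounds below may be only part of what the source reports. "The series", "measured", "known", "first", "only" and "open" are said of these compounds alone.

Compound 1 `COC(=O)c1ccc(NCc2cncn2Cc2cccc(C)c2)cc1-c1ccccc1`, compound 2 `COC(=O)c1ccc(NCc2cncn2Cc2ccc(Cl)cc2)cc1-c1ccccc1` and compound 3 `COC(=O)c1ccc(NCc2cncn2Cc2ccc(C(C)(C)C)cc2)cc1-c1ccccc1` share one core and differ only in the group on the benzyl ring. In a toxicity assay on NIH3T3 cells (Mus musculus) for cytotoxicity, read by resazurin assay (on this read-out higher numbers stand for an effect only at larger amounts of compound and lower numbers for an effect already at smaller amounts), compound 2 gives 25000 nM. For compound 1 this assay reports only a limit, > 10000 nM, because 1 of the 3 values sits at the limit of > 10000 nM in this assay, at which 1 of the 3 values shown sits. Hence the step that the limit leaves unreadable from compound 1 to compound 2 cannot be sized. For compound 3 this assay reports "not determined" (no result reported), so no result at all is available for it. Compound 4 `COC(=O)c1ccc(NCc2cncn2Cc2ccc(Br)cc2)cc1-c1ccccc1` differs from compound 3 by bromo in place of tert-butyl on an aromatic carbon. No measured step bears on this change, so only the two shown values guide an expectation. Compound 4 is expected to give 20000 nM, estimated between 8000 nM and 60000 nM.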

Compound 4, half-maximal effective concentration: > 10000 nM
Compound 4: only a limit was reported; the forecaster's own chance of this, stated with the estimate: 40%; the middle value is on the limit's open side.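

No new step can be read from compound 4 to compound 1 or compound 2, because compound 4 and compound 1 are reported only as limits: the limit of > 10000 nM in this assay, at which 2 of the 4 values shown sit. Going by these compounds, whether bromo and chloro on the benzyl ring differ in this assay stays open.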